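Removing a cyclopropyl from an aromatic nitrogen

A few compounds are considered here, and "the series" means these few. Any claim that something is new, unique, unknown or untested is made for them only; others in the source may bear on it.

Of the compounds shown here, three built on one shared core have been measured in an ADME assay on microsomes from liver (Mus musculus) for metabolic stability, read by LC-MS, using NADPH, with a stated time of 30 min, tested at 1.5 uM; on this read-out lower numbers stand for a less stable compound and higher numbers for a more stable compound. Compound 1 `CC(C1CC1)n1cc(Nc2nc(N)nc(-c3cccc(-n4ccc5cc(C6CC6)cc(F)c5c4=O)c3CO)n2)cn1` gives 1.1%, compound 2 `N#Cc1cc(Nc2nc(N)nc(-c3cccc(-n4ccc5cc(C6CC6)cc(F)c5c4=O)c3CO)n2)cn1C1CC1` gives 21%, and compound 3 `Nc1nc(Nc2cnn(C3CC3)c2)nc(-c2cccc(-n3ccc4cc(C5CC5)cc(F)c4c3=O)c2CO)n1` gives 16%. Compound 3 thus stands second highest of the three: its gap to compound 2 lies within the scatter, while the step of a number 14.9 percentage points higher from compound 1 to compound 3 (beyond the scatter) lies beyond it. Compound 4 `Nc1nc(Nc2cn[nH]c2)nc(-c2cccc(-n3ccc4cc(C5CC5)cc(F)c4c3=O)c2CO)n1` has not yet been measured; it differs from compound 3 by hydrogen in place of cyclopropyl on an aromatic nitrogen. Among the measured compounds shown here, one measured step bears on this change at the same aromatic nitrogen: a number 14.9 percentage points higher from compound 1 to compound 3 (beyond the scatter), a modest gain when the group there was made smaller. The step of a number 19.9 percentage points higher from compound 1 to compound 2 (beyond the scatter) alters another part of the molecule and says less. Resting on a single relevant step, a further cut down to hydrogen is expected to give at most a modest rise, a number 11 percentage points higher from compound 3 to compound 4 (beyond the scatter), and possibly nothing beyond the scatter. Compound 4 is therefore estimated at 27%, within a range from 12% to 50%.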

Compound 4, percent of the compound remaining: 39%
Compound 4: middle estimate off by 12 percentage points, on the low side; low and high end bracket the measured number.
By their numbers in this assay, from the lowest: compound 1; then compounds 3 and 2 (each within the scatter of the next); then compound 4.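

In this assay, removing the cyclopropyl altogether gives a number 23 percentage points higher from compound 3 to compound 4 (beyond the scatter) and shows that the aromatic nitrogen needs no carbon group at all for the number to rise further. At this nitrogen, the numbers climb at each cut from 1-cyclopropylethyl to cyclopropyl to hydrogen, and the whole change amounts to a number 37.9 percentage points higher from compound 1 to compound 4 (beyond the scatter). Compounds 2 and 3 lie within the scatter of each other, but the 1H-pyrazol-4-yl group now separates itself from the 5-cyano-1-cyclopropyl-1H-pyrrol-3-yl group, with a number 18 percentage points higher from compound 2 to compound 4 (beyond the scatter).

Nothing shown here gives a reason for these rises. On these data alone, it remains open whether a methyl or a short chain ending in a hydroxyl on this aromatic nitrogen would keep the number as high as hydrogen does.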